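Swapping the Vinylsulfonyl Group on the Ring Nitrogen of Compound 2

The source may report more compounds than this note shows. Statements on the series, on what has been measured and on what is new or still open speak of the compounds shown alone.

Of the compounds shown here, three sharing one core have been tested in a functional assay on MDA-MB-436 cells (Homo sapiens) for antiproliferative activity, read by MTT assay, with a stated time of 48 h; on this read-out lower numbers stand for stronger inhibition and higher numbers for weaker inhibition. Compound 1 `C=CS(=O)(=O)N1CCN(c2ncnc3sc(-c4ccc(OC)cc4)cc23)CC1` gives 28400 nM. Compound 2 `C=CS(=O)(=O)N1CCN(c2ncnc3sc(-c4ccc(N5CCN(C)CC5)cc4)cc23)CC1` gives 8760 nM, the second highest of the three numbers; it is separated from compound 1 by a 3.2-fold lower number from compound 1 to compound 2 (0.51 log units; beyond the scatter) and from compound 3 `C=CS(=O)(=O)N1CCN(c2ncnc3sc(-c4ccc(N5CCN(C)CC5)cc4)cc23)[C@@H](C)C1`, which gives 6920 nM, by a 1.3-fold lower number from compound 2 to compound 3 (0.10 log units; within the scatter). Compound 4 `CN1CCN(c2ccc(-c3cc4c(N5CCN(C(=O)Nc6ccc(F)cc6F)CC5)ncnc4s3)cc2)CC1` has not yet been measured and differs from compound 2 in a single place: (2,4-difluorophenyl)carbamoyl in place of vinylsulfonyl on an amine nitrogen in a ring. Going by the values given here, neither measured step touches that ring nitrogen, so no measured step bears directly on this change, and the expected outcome is no step beyond the scatter in either direction, with wide uncertainty. On that basis compound 4 is expected to give 9000 nM, within an estimated range from 2500 nM to 35000 nM, which corresponds to an expected step of a 1.0-fold higher number from compound 2 to compound 4 (0.01 log units; within the scatter).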

Compound 4, half-maximal inhibitory concentration: 20200 nM
Estimate against measurement, compound 4: 2.2-fold (0.35 log units) below; low and high end bracket the measured number.
By their numbers in this assay, from the lowest: compounds 3 and 2 (each within the scatter of the next); then compounds 4 and 1 (each within the scatter of the next).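

In this assay, (2,4-difluorophenyl)carbamoyl in place of vinylsulfonyl on the ring nitrogen gives a 2.3-fold higher number from compound 2 to compound 4 (0.36 log units; beyond the scatter), so this position does influence the read-out, though only modestly. The larger group with its aromatic ring still leaves a number in the same broad range as the other compounds, so vinylsulfonyl is not needed for a measurable value here. Nothing available explains this rise.

From the compounds shown here alone, the swap changes both the link to the ring nitrogen and the group beyond it, so the contribution of each remains unknown. A plain acetyl group or an unsubstituted phenylcarbamoyl group at this nitrogen could help separate the two.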